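Shortening the Side Chain of Compound 2

This account rests on a few compounds, and the source may have more. Where it says the series, first, only, none or still open, it means among the compounds named here.

Among the measured compounds shown here, in a functional assay on MCF7 cells (Homo sapiens) for cytotoxicity, read by MTT assay, with a stated time of 48 h (on this read-out higher numbers stand for weaker inhibition and lower numbers for stronger inhibition), compound 1 (`CCCCCCC(O)C/C=C\CCCCCCCC1=NNC2SCC(c3ccccc3)=NN12`) gives 8590 nM and compound 2 (`CCCC/C=C\CCC(O)CCCCCCC1=NNC2SCC(c3ccccc3)=NN12`) gives 8800 nM with the two numbers within the scatter of each other, so compound 2 stands level with its only measured neighbour. Compound 3 (`C=CCCCCCCCCC1=NNC2SCC(c3ccccc3)=NN12`) has not yet been measured. It keeps the shared core but carries but-3-en-1-yl in place of 1-hydroxynon-4-en-1-yl on a saturated chain carbon, six bonds along the chain from a carbon with a double bond to nitrogen, and the change counts as but-3-en-1-yl in place of 1-hydroxynon-4-en-1-yl on a saturated chain carbon, six bonds along the chain from a carbon with a double bond to nitrogen in all. For the measured compounds named here, no measured pair shows what such a change does, so no step clearly beyond the scatter is expected. The expected step is a 1.3-fold higher number from compound 2 to compound 3 (0.10 log units; within the scatter) and it leans slightly towards weaker inhibition. In this assay compound 3 is estimated at 11000 nM (expected range 4500 nM to 27000 nM).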

Compound 3, half-maximal inhibitory concentration: 10300 nM
Compound 3: middle estimate off by 1.1-fold (0.03 log units), on the high side; the range from low to high includes it.
By their numbers in this assay, from the lowest: compounds 1, 2 and 3 (each within the scatter of the next).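

In this assay, but-3-en-1-yl in place of 1-hydroxynon-4-en-1-yl gives a 1.2-fold higher number from compound 2 to compound 3 (0.07 log units; within the scatter), and allyl in place of 4-hydroxydec-1-en-1-yl gives a 1.2-fold higher number from compound 1 to compound 3 (0.08 log units; within the scatter). Among the compounds shown here, these are the first steps read at this part of the side chain, and they show that a group of 4 heavy atoms with 0 hydrogen-bond donors and 0 hydrogen-bond acceptors stands level with one of 10 heavy atoms carrying 1 of each, so neither the size of this exchange nor the loss of the hydroxyl leaves a mark beyond the scatter. Nothing at hand offers an explanation for this result.

Still open, going by these compounds, is whether an amine or a carboxylic acid in place of but-3-en-1-yl would give a step beyond the scatter. The three compounds also leave open what a much shorter chain, such as methyl, would do in this assay.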